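A few compounds are considered here, and "the series" means these few. Any claim that something is new, unique, unknown or untested is made for them only; others in the source may bear on it.

In a functional assay on BGC-823 cells (Homo sapiens) for cytotoxicity, read by MTT assay, with a stated time of 48 h (a higher number here means a weaker inhibitor, a lower number a stronger inhibitor), compound 1 (`NNC(=O)CSc1nnc(-c2ccncc2)o1`) gives 3260 nM and compound 2 (`O=C(CSc1nnc(-c2ccncc2)o1)N/N=C/c1cccc(F)c1`) gives 27500 nM while compound 3 (`O=C(CSc1nnc(-c2ccncc2)o1)N/N=C/c1cc(Cl)cc(Cl)c1O`) gives 6340 nM as its number. Compound 3 therefore lies within the scatter of compound 1 and clearly under compound 2. Compound 4 (`O=C(CSc1nnc(-c2ccncc2)o1)N/N=C/c1ccco1`) differs from compound 3 in one place: furan-2-yl in place of 3,5-dichloro-2-hydroxyphenyl on a carbon with a double bond to nitrogen. Going by the values given here, the only measured step involving that group is a 4.3-fold lower number from compound 2 to compound 3 (0.64 log units; beyond the scatter) with 3,5-dichloro-2-hydroxyphenyl in place of 3-fluorophenyl. Losing that group is therefore expected to raise the number in this assay by a similar or smaller amount. The expected move is a 2.2-fold higher number from compound 3 to compound 4 (0.34 log units; beyond the scatter) for this exchange. For compound 4 the estimated value is 14000 nM with an expected range from 5000 nM to 40000 nM across repeated measurements.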

Compound 4, half-maximal inhibitory concentration: 25800 nM
Estimate against measurement, compound 4: 1.8-fold (0.27 log units) below; measured number inside the range.
By their numbers in this assay, from the lowest: compounds 1 and 3 (each within the scatter of the next); then compounds 4 and 2 (each within the scatter of the next).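

In this assay, the place on the carbon with a double bond to nitrogen responds in both directions around 3,5-dichloro-2-hydroxyphenyl: furan-2-yl in its place gives a 4.1-fold higher number from compound 3 to compound 4 (0.61 log units; beyond the scatter). Furan-2-yl and 3-fluorophenyl cannot be told apart, with a 1.1-fold lower number from compound 2 to compound 4 (0.03 log units; within the scatter), while building the furan-bearing group onto the amide-type nitrogen of compound 1 gives a 7.9-fold higher number from compound 1 to compound 4 (0.90 log units; beyond the scatter). Nothing available explains these differences. On these data alone, it remains open whether the two chlorines or the hydroxyl carry the difference seen with compound 3. Also open, as far as these compounds go, is how a plain phenyl, a pyridine or an amine-bearing ring would behave at this place.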